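Acetamido to propanoylamino on the deprotected core

A few compounds are considered here, and "the series" means these few. Any claim that something is new, unique, unknown or untested is made for them only; others in the source may bear on it.

Compound 1, `CC(C)C(=O)Nc1ccc(C(=O)Nc2ccn([C@H]3CC[C@H](O[C@H]4O[C@H](C)[C@@H](N(C)C)[C@H](O)[C@H]4O)[C@@H](C)O3)c(=O)n2)cc1`, 6630 nM
Compound 2, `CC(=O)Nc1ccn([C@H]2CC[C@H](O)[C@@H](C)O2)c(=O)n1`, > 20000 nM

In a functional assay on HCT-116 cells (Homo sapiens) for cytotoxicity, read by sulforhodamine B assay, with a stated time of 24 h (on this read-out higher numbers stand for weaker inhibition and lower numbers for stronger inhibition), compound 1 gives 6630 nM. Compound 2 gives > 20000 nM, which is a limit of this assay and not a number. Compound 2 thus stands at the limit of > 20000 nM in this assay, at which 1 of the 2 values shown sits. Compound 3, `CCC(=O)Nc1ccn([C@H]2CC[C@H](O)[C@@H](C)O2)c(=O)n1`, is not yet measured and differs from compound 2 by methyl in place of hydrogen on a saturated chain carbon bound to a carbonyl carbon. Among the measured compounds shown here, no measured pair shows this step. In this assay no change beyond the usual scatter is expected. The step that the limit leaves unreadable from compound 2 to compound 3 is the expected size. Compound 3 is estimated at 30000 nM, between 15000 nM and 80000 nM, most probably again reported as a limit.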

Compound 3, half-maximal inhibitory concentration: > 20000 nM
Compound 3 ended at the assay's limit; the forecaster's own chance of this, stated with the estimate: 85%; the middle value does not contradict the limit.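

Compound 2 and compound 3 both end at a limit rather than a number, so the change from acetamido to propanoylamino gives no readable step. From the compounds shown here alone, whether this change affects cytotoxicity on the shared core remains open.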